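The compounds below may be only part of what the source reports. "The series", "measured", "known", "first", "only" and "open" are said of these compounds alone.

Compound 1 `CCOC(=O)c1ccc2oc(N3CCN(C)CC3)nc2c1` carries an ethoxycarbonyl group on its aromatic ring and, in a functional assay on ileum (strain Hartley) for agonist activity at 5-hydroxytryptamine receptor 3A (Cavia porcellus) (on this read-out higher numbers stand for higher potency (the scale is a negative logarithm) and lower numbers for lower potency), compound 1 gives only a limit, < 4. Compound 2 `CN1CCN(c2nc3cc(N)ccc3o2)CC1` carries an amino group at the same place, and in this assay compound 2 gives 4.97. Among the compounds with values here, the move a number at least 0.97 log units higher from compound 1 to compound 2 (beyond the scatter) is the only measured step here. Within the data shown here, compound 2 therefore holds the only real number in this assay; the one other value is a limit (the limit of < 4 in this assay, at which 1 of the 2 values shown sits).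

Compound 3 `CC(=O)c1ccc2oc(N3CCN(C)CC3)nc2c1` is the next case. It differs from compound 2 in one place: acetyl in place of amino on an aromatic carbon. The acetyl group, like the ethoxycarbonyl group of compound 1, contains a carbonyl, so the change runs back toward the kind of substituent that compound 1 bears. Because the step from compound 1 to compound 2 was a number at least 0.97 log units higher from compound 1 to compound 2 (beyond the scatter), the reverse direction is expected here, and in this assay the step of a number 0.77 log units lower from compound 2 to compound 3 (beyond the scatter) is the estimate for compound 3. Compound 3 is expected to give about 4.2, within a range from 3.6 to 4.9.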

Compound 3, negative logarithm of the half-maximal effective concentration: < 4
Compound 3 was reported as a limit (the forecaster's own chance of this, stated with the estimate: 40%); middle value at least 0.20 log units away from the limit.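

In this assay, acetyl in place of amino on this aromatic carbon gives a number at least 0.97 log units lower from compound 2 to compound 3 (beyond the scatter). Two different carbonyl-bearing groups at this place, ethoxycarbonyl in compound 1 and acetyl in compound 3, now end in a limit rather than a number, so among these compounds only the amino group of compound 2 gives a real value. The step between compound 1 and compound 3 cannot be read, because both of their values are limits, so swapping ethoxy for methyl on the carbonyl carbon shows no measurable change in either direction: the limit of < 4 in this assay, at which 2 of the 3 values shown sit.

The compounds shown leave open whether any group other than amino at this place, such as a hydroxyl or a methylamino group, would also give a real number in this assay. The amino group has 1 hydrogen-bond donor and 1 heavy atom, while acetyl has 0 hydrogen-bond donors and 3 heavy atoms, and these compounds cannot separate those two differences from each other.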